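Halogen and methyl variation on the arylamino group

The source may hold more compounds than are shown below. What is called first, only, known or untested is meant among the compounds shown, and "the series" means these compounds.

The series shares one core, shown for compound 1 as `Cc1n[nH]c2ccc(-c3nc4cnc(N5CCN(C)CC5)cn4c3Nc3ccc(F)cc3)cc12` and for compound 2 as `Cc1n[nH]c2ccc(-c3nc4cnc(N5CCN(C)CC5)cn4c3Nc3ccc(Cl)cc3)cc12`; the two differ only in a single substituent on one aromatic carbon. In a functional assay on MV4-11 cells (Homo sapiens) for inhibition, with a stated time of 120 h (on this read-out lower numbers stand for stronger inhibition and higher numbers for weaker inhibition), compound 1 gives 32300 nM, while compound 2 gives 3510 nM, and the step of a 9.2-fold lower number from compound 1 to compound 2 (0.96 log units; beyond the scatter) is the only measured step among these compounds. Compound 3 has the structure `Cc1ccc(C)c(Nc2c(-c3ccc4[nH]nc(C)c4c3)nc3cnc(N4CCN(C)CC4)cn23)c1`; in this assay compound 3 gives "not determined" (no result reported), so it stands on no number of its own, and nothing can be said about how it compares with compound 1 or compound 2. Compound 4 has the structure `Cc1cc(Br)ccc1Nc1c(-c2ccc3[nH]nc(C)c3c2)nc2cnc(N3CCN(C)CC3)cn12`. The change from compound 3 to compound 4 is 4-bromo-2-methylphenyl in place of 2,5-dimethylphenyl on a nitrogen on an aromatic ring. Among the measured compounds shown here, no measured step covers this exchange directly; the one step that bears on it at all, a 9.2-fold lower number from compound 1 to compound 2 (0.96 log units; beyond the scatter), shows that chloro in place of fluoro gave a lower number, but that exchange involved neither a methyl nor a bromine, and compound 3 carries no value to step from. On that footing the number for compound 4 in this assay is expected to lie at about 2000 nM, with a range from 400 nM to 10000 nM.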

Compound 4, half-maximal inhibitory concentration: 10900 nM
Estimate against measurement, compound 4: 5.5-fold (0.74 log units) below, and the stated range ends below it.
By their numbers in this assay, from the lowest: compound 2; then compound 4; then compound 1.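

In this assay, the exchange of 4-chlorophenyl for 4-bromo-2-methylphenyl on the nitrogen gives a 3.1-fold higher number from compound 2 to compound 4 (0.49 log units; beyond the scatter), while the exchange of 4-fluorophenyl for the same group gives a 3.0-fold lower number from compound 1 to compound 4 (0.47 log units; beyond the scatter), so compound 4 falls between the two earlier compounds. The drop seen on going from fluoro to chloro therefore does not carry on to this bromine- and methyl-bearing group, although the new group differs from both earlier aryl groups in the halogen and in the methyl, so neither change can be credited alone, and the step from compound 3 to compound 4 cannot be read, compound 3 having no number. Nothing at hand accounts for the position of compound 4 among these values.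

The compounds shown leave open how a bromine without the methyl would read at this place, and how far a methyl alone moves the number. They also leave open whether a methoxy group, a nitrile or a trifluoromethyl group on the phenyl ring would fall within the span set by compound 1 and compound 2.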